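Chloro to methoxy on the pendant aryl of a chalcone series

The compounds below may be only part of what the source reports. "The series", "measured", "known", "first", "only" and "open" are said of these compounds alone.

Of the compounds shown here, two carry a number so far. Compound 1 `COc1cc(/C=C/C(=O)c2cccc(-n3cc(-c4ccc(Cl)cc4)[nH]c3=O)c2)cc(OC)c1OC` gives 3490 nM in a functional assay on SF-539 cells (Homo sapiens) for inhibition (a lower number here means a stronger inhibitor of growth, a higher number a weaker inhibitor of growth), the highest of the two numbers, and compound 2 `O=C(/C=C/c1cccc(O)c1)c1cccc(-n2cc(-c3ccc(Cl)cc3)[nH]c2=O)c1` gives 1680 nM in this assay, a lower number that lies beyond the scatter; the two compounds differ in more than one place, so the pair shows only its two values. Compound 3 `COc1ccc(-c2cn(-c3cccc(C(=O)/C=C/c4cc(OC)c(OC)c(OC)c4)c3)c(=O)[nH]2)cc1` is not yet measured. It differs from compound 1 by methoxy in place of chloro on an aromatic carbon, described as methoxy in place of chloro on an aromatic carbon, para to a large group on the aryl. Among the compounds with values here, no single-change step between measured compounds is at hand, so no size of step can be read off; a small step in either direction, not clearly beyond the scatter, is expected from compound 1 to compound 3 as a 1.2-fold lower number from compound 1 to compound 3 (0.07 log units; within the scatter). Compound 3 is estimated at 3000 nM in this assay, with a range from 1200 nM to 8000 nM.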

Compound 3, concentration for 50% growth inhibition: 2000 nM
Estimate against measurement, compound 3: 1.5-fold (0.18 log units) above; the measured number falls inside the stated range.
By their numbers in this assay, from the lowest: compounds 2, 3 and 1 (each within the scatter of the next, the first and the last beyond it).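

Within the data shown here, the 4-chlorophenyl to 4-methoxyphenyl change gives the first single-change step, and in this assay it reads as a 1.7-fold lower number from compound 1 to compound 3 (0.24 log units; within the scatter) and stays within the scatter. Growth inhibition at this position therefore holds up when chloro gives way to methoxy, a group with one more heavy atom and a hydrogen-bond acceptor, though a single step cannot show a trend. Nothing available accounts for the size of this step.

The compounds shown leave open how an amine, a carboxylic acid or a longer alkoxy chain would read in this same place on the aryl. They also leave open whether the change from chloro to methoxy gives a similar step on the core of compound 2, which differs from compound 1 in more than one place.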